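Sulfonamide nitrogen substituents in a dichlorobenzamide series

The source may report more compounds than this note shows. Statements on the series, on what has been measured and on what is new or still open speak of the compounds shown alone.

Measured so far in a functional assay on HEK293 cells for agonist activity at probable G-protein coupled receptor 27 (Homo sapiens), read by a luciferase reporter and beta-arrestin recruitment, with a stated time of 10 min; on this read-out lower numbers stand for an effect already at smaller amounts and higher numbers for an effect only at larger amounts of compound:
compound 1, `CN(c1ccccc1)S(=O)(=O)c1ccc(NC(=O)c2ccc(Cl)cc2Cl)cc1`, gives 2570 nM.
compound 2, `O=C(Nc1ccc(S(=O)(=O)NCc2ccccc2)cc1)c1ccc(Cl)cc1Cl`, gives only the limit > 100000 nM.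
compound 3, `Cc1cc(Br)ccc1C(=O)Nc1ccc(S(=O)(=O)Nc2ccccc2)cc1`, gives 851 nM.

Compound 2 thus stands at the edge of what this assay reports: its value is a limit, not a number, and it sits at the limit of > 100000 nM in this assay, at which 1 of the 3 values shown sits. Compound 1 and compound 3 both give numbers well inside the range.

The next compound, compound 4, `O=C(Nc1ccc(S(=O)(=O)Nc2cccc(Cl)c2)cc1)c1ccc(Cl)cc1Cl`, differs from compound 2 in one place: 3-chlorophenyl in place of benzyl on a sulfonamide nitrogen.

Within the data shown here, the one measured step that bears on this change is an at least 38-fold higher number from compound 1 to compound 2 (1.59 log units; beyond the scatter). That step goes from an aryl-bearing sulfonamide nitrogen to a benzyl-bearing one and is large; the change from compound 2 to compound 4 reverses that kind of exchange, putting an aryl group back on the sulfonamide nitrogen. Compound 1 and compound 3, both with an aryl group on that nitrogen, give numbers rather than limits. A large step in this assay toward an effect at smaller amounts is therefore expected. It is estimated as an at least 66-fold lower number from compound 2 to compound 4 (1.82 log units; beyond the scatter). Compound 4 is expected to give 1500 nM in this assay, within a range of 300 nM to 10000 nM.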

Compound 4, half-maximal effective concentration: 575 nM
For compound 4 the middle estimate is 2.6-fold (0.42 log units) above the measured one, and the stated range covers the measured number.
By their numbers in this assay, from the lowest: compounds 4 and 3 (each within the scatter of the next); then compound 1. At a limit, above all of these: compound 2.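

In this assay, putting 3-chlorophenyl in place of benzyl on a sulfonamide nitrogen, with the dichlorobenzamide part held fixed, gives an at least 170-fold lower number from compound 2 to compound 4 (2.24 log units; beyond the scatter), a large step that restores a measurable number. The value of compound 2 is a limit and not a number, so the size of this step is only a bound: the limit of > 100000 nM in this assay, at which 1 of the 4 values shown sits. Set against compound 1, the exchange of methyl(phenyl)amino for (3-chlorophenyl)amino on the sulfonyl sulfur gives a 4.5-fold lower number from compound 1 to compound 4 (0.65 log units; beyond the scatter), a modest step beyond the scatter, which shows that the methyl group on that nitrogen is not needed for a number in this assay and that its absence alone does not account for the limit at compound 2.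

This step combines the loss of the methyl group with the entry of chlorine, and no pair shown separates the two, so the share of each stays open. Also open, from the compounds shown here alone, is how far this nitrogen accepts other groups, such as a pyridine ring, a cyclohexyl ring or a phenethyl chain, or an aryl ring carrying an amine or a carboxylic acid.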